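The source may report more compounds than this note shows. Statements on the series, on what has been measured and on what is new or still open speak of the compounds shown alone.

Measured compounds in a functional assay on NCI/ADR-RES cells (Homo sapiens) for inhibition, read by sulforhodamine B assay, with a stated time of 48 h; on this read-out lower numbers stand for stronger inhibition of growth and higher numbers for weaker inhibition of growth:

Compound 1 `COc1cc(-c2cc(/C=C/C(=O)c3ccc(Cl)c(Cl)c3)[nH]n2)cc(OC)c1OC` gives 10600 nM
Compound 2 `COc1ccc(C(=O)/C=C/c2cc(-c3cc(OC)c(OC)c(OC)c3)n[nH]2)cc1OC` gives 3130 nM
Compound 3 `COc1ccc(C(=O)/C=C/c2cc(-c3cc(OC)c(OC)c(OC)c3)n[nH]2)cc1` gives 2700 nM

Compound 2 holds the second highest number of the three. Its nearest neighbour is compound 3, with a 1.2-fold lower number from compound 2 to compound 3 (0.06 log units; within the scatter), a gap that lies within the scatter. Its furthest neighbour is compound 1: the step of a 3.4-fold lower number from compound 1 to compound 2 (0.53 log units; beyond the scatter) is modest but beyond the scatter.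

Compound 4 `COc1cc(C(=O)/C=C/c2cc(-c3cc(OC)c(OC)c(OC)c3)n[nH]2)cc(OC)c1OC` differs from compound 2 by one change: methoxy in place of hydrogen on an aromatic carbon. The ring that carries this change already bears two methoxy groups in compound 2.

Among the compounds with values here, the step that bears most directly on this change is the one from compound 2 to compound 3, in which a methoxy was removed from the same ring: a 1.2-fold lower number from compound 2 to compound 3 (0.06 log units; within the scatter), within the scatter. The other two steps, a 3.4-fold lower number from compound 1 to compound 2 (0.53 log units; beyond the scatter) and a 3.9-fold lower number from compound 1 to compound 3 (0.59 log units; beyond the scatter), replace the whole dichlorophenyl ring and so speak less directly. Adding a third methoxy is therefore expected to give no step beyond the scatter in this assay.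

For compound 4 the estimated value is 3200 nM, with a range from 1300 nM to 8000 nM, which means an expected step of a 1.0-fold higher number from compound 2 to compound 4 (0.01 log units; within the scatter).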

Compound 4, concentration for 50% growth inhibition: 3470 nM
Compound 4: middle estimate off by 1.1-fold (0.04 log units), on the low side; the range from low to high includes it.
By their numbers in this assay, from the lowest: compounds 3, 2 and 4 (each within the scatter of the next); then compound 1.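

In this assay, the step of a 1.1-fold higher number from compound 2 to compound 4 (0.04 log units; within the scatter) lies within the scatter, so no gain or loss can be read from placing a methoxy on this aromatic carbon, ortho to a methoxy group and meta to a large group. The earlier step of a 1.2-fold lower number from compound 2 to compound 3 (0.06 log units; within the scatter) is also within the scatter, so this ring has now been seen with one, two and three methoxy groups, and neither step from compound 2 can be told apart from repeat-measurement noise. Nothing measured here offers an explanation for this.

The compounds shown leave open whether a group of another kind at this place, such as an amine or a carboxylic acid, would also stay within the scatter. They also leave open what a longer chain, such as ethoxy in place of methoxy, would do here.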